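A few compounds are considered here, and "the series" means these few. Any claim that something is new, unique, unknown or untested is made for them only; others in the source may bear on it.

For the measured compounds named here, in a functional assay on U-937 cells (Homo sapiens) for antiproliferative activity, read by MTT assay, with a stated time of 24 h (on this read-out lower numbers stand for stronger inhibition and higher numbers for weaker inhibition), only two related compounds have readings so far. Compound 1 `COc1cc(Nc2nccc(-c3ccc([N+](=O)[O-])cc3F)n2)cc(OC)c1OC` gives 23100 nM. Compound 2 `COc1cc(Nc2nccc(NCCCN)n2)cc(OC)c1OC`, which carries a (3-aminopropyl)amino group, gives > 50000 nM, and that figure is a limit of the assay, not a number. Compound 2 therefore stands at the limit of > 50000 nM in this assay, at which 1 of the 2 values shown sits.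

Compound 3 `COc1cc(Nc2ncc(I)c(NCCCN)n2)cc(OC)c1OC` changes compound 2 in one place: iodo in place of hydrogen on an aromatic carbon, ortho to the (3-aminopropyl)amino group. Going by the values given here, no measured pair shows what this change does in this assay. Among the compounds with values here, the only firm number nearby is that of compound 1 at 23100 nM, so a modest move toward stronger inhibition is expected. A reading again at the limit remains quite possible. The expected size of the change is an at least 1.4-fold lower number from compound 2 to compound 3 (0.15 log units; that floor lies within the scatter). For compound 3 the estimated value is 35000 nM, within an expected range of 12000 nM to 70000 nM.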

Compound 3, half-maximal inhibitory concentration: 39900 nM
For compound 3 the middle estimate is 1.1-fold (0.06 log units) below the measured one, and the stated range covers the measured number.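

In this assay, for the compounds shown here, iodo in place of hydrogen on the aromatic carbon ortho to the (3-aminopropyl)amino group gives the first reading of a change at this position: an at least 1.2-fold lower number from compound 2 to compound 3 (0.09 log units; that floor lies within the scatter). Compound 3 has a firm number where compound 2 has only a limit, which gives this aminopropyl compound a reading within the range of the assay. That floor does not settle whether the iodo truly changes the inhibition, as the figure for compound 2 is a limit and not a number: the limit of > 50000 nM in this assay, at which 1 of the 3 values shown sits.

The compounds shown leave open whether a chloro, a methyl or a nitrile on this aromatic carbon would read like iodo. They also leave open how the reading of compound 3 would respond if a longer chain or a carboxylic acid took the place of the (3-aminopropyl)amino group.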